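Two compounds at the assay limit, and a third

The source may report more compounds than this note shows. Statements on the series, on what has been measured and on what is new or still open speak of the compounds shown alone.

Compound 1 `Cc1ccc(C2=NN(c3ccc(S(C)(=O)=O)cc3)C(=O)CC2)cc1` gives > 100000 nM as a limit
Compound 2 `Cc1cc(O)ccc1C1=NN(c2ccc(S(C)(=O)=O)cc2)C(=O)CC1` gives > 100000 nM as a limit

Both compounds were read in a functional assay on HCT-15 cells (Homo sapiens) for inhibition, read by sulforhodamine B assay, with a stated time of 48 h (a lower number here means a stronger inhibitor of growth, a higher number a weaker inhibitor of growth), and neither gave a number. Compound 2 stands at > 100000 nM which is a limit of the assay and not a number. Compound 1 shows > 100000 nM which is a limit as well.

The compound still to be measured is compound 3 `CCc1ccc(C2=NN(c3ccc(S(C)(=O)=O)cc3)C(=O)CC2)cc1` which carries 4-ethylphenyl in place of 4-hydroxy-2-methylphenyl on a carbon with a double bond to nitrogen. For the measured compounds named here, the one measured step at that place is a step that the two limits leave unreadable from compound 1 to compound 2 and it gives no size to carry over. Going by the values given here, the only other guide is the limit of > 100000 nM in this assay, at which 2 of the 2 values shown sit, and it too offers no size. For compound 3, no step beyond the scatter is expected in this assay and no direction can be named. The estimate means a number no higher from compound 2 to compound 3 (the limit leaves the size open) as the expected step. Compound 3 is estimated at 100000 nM with an expected range from 40000 nM to 250000 nM and a limit of the assay is expected again.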

Compound 3, concentration for total growth inhibition: > 100000 nM
Compound 3: only a limit was reported; the forecaster's own chance of this, stated with the estimate: 80%; the middle value lies on the limit itself.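

Compound 3 gives > 100000 nM in this assay, which is a limit of the assay and not a number. For the compounds shown here, no step among compound 1, compound 2 and compound 3 can be read: the limit of > 100000 nM in this assay, at which 3 of the 3 values shown sit. The compounds shown leave open whether any group at this place on the shared core would give a readable value in this assay.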